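This account rests on a few compounds, and the source may have more. Where it says the series, first, only, none or still open, it means among the compounds named here.

Compound 1, `O=C(c1ccc(-c2nc(CS(=O)(=O)c3cccs3)no2)s1)C(F)(F)F`: 520 nM
Compound 2, `O=C(c1ccc(-c2ncc(-c3ccccc3)s2)s1)C(F)(F)F`: 1350 nM
Compound 3, `O=C(c1ccc(-c2nc(-c3ccc(F)cc3F)no2)s1)C(F)(F)F`: 580 nM

These three compounds share a common core and were each tested in an assay on isolated protein for inhibition of protein deacetylase HDAC6 (Homo sapiens); a higher number here means a weaker inhibitor, a lower number a stronger inhibitor. Compound 3 stands at the second highest of the three numbers. Its gap to compound 1 is within the scatter of repeated measurements, so the two cannot be told apart on these data. Compound 2 gives a number beyond the scatter higher than compound 3, so compound 2 is the weaker inhibitor of that pair.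

Compound 4, `O=C(c1ccc(-c2nc(-c3cccs3)no2)s1)C(F)(F)F`, has not yet been measured. It differs from compound 3 in a single place: thiophen-2-yl in place of 2,4-difluorophenyl on an aromatic carbon. Among the measured compounds shown here, no measured pair in this set differs in exactly this way, so the size of the step can only be guessed from what is at hand. Compound 1 also carries a thiophen-2-yl, though attached through a longer link, and in this assay compound 1 gives 520 nM, close to compound 3.

The expected step is therefore a 1.2-fold lower number from compound 3 to compound 4 (0.06 log units; within the scatter), small and not beyond the scatter in either direction. Compound 4 is estimated at 500 nM, with a likely range from 200 nM to 1300 nM.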

Compound 4, half-maximal inhibitory concentration: 670 nM
Compound 4: middle estimate off by 1.3-fold (0.13 log units), on the low side; measured number inside the range.
By their numbers in this assay, from the lowest: compounds 1, 3, 4 and 2 (each within the scatter of the next, the first and the last beyond it).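

In this assay, replacing the 2,4-difluorophenyl with thiophen-2-yl on this aromatic carbon gives a 1.2-fold higher number from compound 3 to compound 4 (0.06 log units; within the scatter), so the two compounds cannot be told apart. Among the compounds shown here, this is the first direct one-place comparison in the set, and it shows that two quite different aromatic rings can occupy this carbon with no measurable difference in this assay: a six-membered ring of carbon only with 8 heavy atoms leaves, and a five-membered ring with 5 heavy atoms, including a sulfur, enters. Nothing available here explains why the exchange makes no clear difference, as no supporting measurement bears on it.

Both groups in this comparison are aromatic rings joined directly to the same carbon, so the result says nothing about how a non-aromatic group, such as an amine, a carboxylic acid or a plain butyl chain, would behave there. From the compounds shown here alone, it also remains open whether a six-membered aromatic ring containing nitrogen, such as pyridin-3-yl, would give a number that can be told apart from those of compound 3 and compound 4.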